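Bromobenzyl Triazole Chalcones Against Lung Carcinoma Cells

The compounds below may be only part of what the source reports. "The series", "measured", "known", "first", "only" and "open" are said of these compounds alone.

Compound 1 `O=C(/C=C/c1ccc(OCc2cn(Cc3ccccc3Br)nn2)cc1)c1ccc(Br)cc1` gives 44% in a functional assay on A549 cells (Homo sapiens) for inhibition, read by MTT assay, with a stated time of 48 h, tested at 10 uM; a lower number here means less inhibition of growth, a higher number more inhibition of growth at the concentration tested.
Compound 2 `O=C(/C=C/c1ccc(OCc2cn(Cc3cccc(Br)c3)nn2)cc1)c1ccc(Br)cc1` gives 44% in this assay.
Compound 3 `O=C(/C=C/c1ccc(OCc2cn(Cc3ccccc3Br)nn2)cc1)c1ccc([N+](=O)[O-])cc1` gives 42% in this assay.

Of the compounds shown here, three of this set have been measured in this assay. The change from compound 1 to compound 2, (3-bromophenyl in place of 2-bromophenyl on a saturated chain carbon bound to an aromatic nitrogen), made a step of no change at the digits printed from compound 1 to compound 2 (within the scatter). Compound 3 differs from compound 1 in its core by nitro in place of bromo on an aromatic carbon, and that step was a number 2 percentage points lower from compound 1 to compound 3 (within the scatter). Among the three, compound 3 holds the lowest number, but its gaps to compound 1 and compound 2 are both within the scatter, so no order among them can be claimed.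

Compound 4 `O=C(/C=C/c1ccc(OCc2cn(Cc3cccc(Br)c3)nn2)cc1)c1ccc([N+](=O)[O-])cc1` has not yet been measured. It differs from compound 3 by 3-bromophenyl in place of 2-bromophenyl on a saturated chain carbon bound to an aromatic nitrogen, which is the same change as that from compound 1 to compound 2, at the same place. Because that earlier step was no change at the digits printed from compound 1 to compound 2 (within the scatter), the step from compound 3 to compound 4 is expected to be of the same size, no change at the digits printed from compound 3 to compound 4 (within the scatter). For compound 4 in this assay the estimate is 42%, expected to lie between 32% and 52%.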

Compound 4, percent growth inhibition at one concentration: 28%
For compound 4 the middle estimate is 14 percentage points above the measured one, outside the stated range (below it).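

In this assay, the change from 2-bromobenzyl to 3-bromobenzyl gave a number 14 percentage points lower from compound 3 to compound 4 (beyond the scatter), and nitro in place of bromo on an aromatic carbon gave a number 16 percentage points lower from compound 2 to compound 4 (beyond the scatter). Both steps are beyond the scatter, yet the same bromine change cannot be said to act differently on the core of compound 3 than on the core of compound 1, nor can it be said to carry over unchanged: the same change on two cores in this assay, no change at the digits printed (within the scatter) from compound 1 to compound 2 and a number 14 percentage points lower (beyond the scatter) from compound 3 to compound 4, 14 percentage points apart, within the scatter of two such steps. The same holds for the nitro change, which these four compounds neither show to depend on the bromobenzyl group present nor show to be independent of it: the same change on two cores in this assay, a number 2 percentage points lower (within the scatter) from compound 1 to compound 3 and a number 16 percentage points lower (beyond the scatter) from compound 2 to compound 4, 14 percentage points apart, within the scatter of two such steps.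

The four compounds form a single square of two changes, so they leave open whether any such dependence is real. Also open, going by these compounds, is whether an amine or a carboxylic acid in place of the nitro group, or a longer chain in place of the benzyl carbon, would follow the steps seen here.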